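The compounds below may be only part of what the source reports. "The series", "measured", "known", "first", "only" and "open" are said of these compounds alone.

Going by the values given here, compound 2 `N#CC[C@]1(n2cc(-c3nc(-c4cn[nH]c4)cn4nccc34)cn2)C[C@@H](C#N)C1` stands at the low end of the three numbers so far in an ADME assay on MDCK-II cells (Canis lupus familiaris) for permeability (a lower number here means that the compound crosses the layer more slowly, a higher number that the compound crosses the layer faster), giving 6 10^-6 cm/s. Its mirror image, compound 1 `N#CC[C@]1(n2cc(-c3nc(-c4cn[nH]c4)cn4nccc34)cn2)C[C@H](C#N)C1`, gives 7 10^-6 cm/s, and the step of a 1.2-fold lower number from compound 1 to compound 2 (0.07 log units; within the scatter) falls within the scatter, so the two configurations are not separated here the fact that compounds 1 and 2 differ only in the configuration as drawn and the value of compound 2 can serve as the starting point. Among the compounds with values here, compound 3 `N#CC[C@]1(n2cc(-c3nc(-c4cc[nH]n4)cn4nccc34)cn2)C[C@H](C#N)C1` gives 17 10^-6 cm/s; the step of a 2.4-fold higher number from compound 1 to compound 3 (0.39 log units; beyond the scatter) is the only measured step that bears on the next change.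

Compound 4 `Cn1ccc(-c2cn3nccc3c(-c3cnn([C@]4(CC#N)C[C@H](C#N)C4)c3)n2)n1` differs from compound 2 in one place: 1-methyl-1H-pyrazol-3-yl in place of 1H-pyrazol-4-yl on an aromatic carbon. Within the data shown here, the shift to a 1H-pyrazol-3-yl attachment is the same as in the step already measured; the methyl on the ring nitrogen has no measured counterpart in this set, so its contribution is unknown. In this assay the step of a 2.8-fold higher number from compound 2 to compound 4 (0.45 log units; beyond the scatter) is therefore expected to be modest and upward, roughly matching the measured shift. Compound 4 is estimated at 17 10^-6 cm/s, with a range of 8 10^-6 cm/s to 35 10^-6 cm/s.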

Compound 4, apparent permeability in the MDCK-II assay: 14 10^-6 cm/s
Estimate against measurement, compound 4: 1.2-fold (0.08 log units) above; the range from low to high includes it.
By their numbers in the MDCK-II assay, from the lowest: compounds 2, 1, 4 and 3 (each within the scatter of the next, the first and the last beyond it).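

In the MDCK-II assay the change to 1-methyl-1H-pyrazol-3-yl on this aromatic carbon reads a 2.3-fold higher number from compound 2 to compound 4 (0.37 log units; beyond the scatter), in the same direction as a 2.4-fold higher number from compound 1 to compound 3 (0.39 log units; beyond the scatter), so the pyrazole carrying a methyl on its ring nitrogen also stands above compound 2. Going by these compounds alone, in a physicochemical assay for lipophilicity, using the shake flask method, in phosphate buffer, measured as octanol-water partition, at pH 7.4 (a lower number here means a more polar compound, a higher number a more lipophilic compound), compound 2 gives 1.6 and compound 4 gives 1.6, with no change at the digits printed from compound 2 to compound 4 (within the scatter), so the upward step has no counterpart in this read-out. Nothing measured in the series accounts for the upward step.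

The step joins a shift of attachment and a methyl, and the compounds shown do not part the two; a 1-methyl-1H-pyrazol-4-yl group would. Going by these compounds, how an ethyl or a chain ending in an amine on that ring nitrogen would read also remains open.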